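The source may hold more compounds than are shown below. What is called first, only, known or untested is meant among the compounds shown, and "the series" means these compounds.

Working notes on the series, cytotoxicity arm.

Of the compounds shown here, three have been measured in an ADME assay on Vero cells (Chlorocebus sabaeus) for cytotoxicity, read by MTT assay, with a stated time of 72 h; a lower number here means a stronger inhibitor, a higher number a weaker inhibitor. Compound 1 `O=C(NNC(=S)NCc1ccccc1)c1cc([N+](=O)[O-])c[nH]1` gives 397000 nM in this assay. Compound 2 `Cn1cc([N+](=O)[O-])cc1C(=O)NNC(=O)Nc1ccc([N+](=O)[O-])cc1` gives 402000 nM in this assay. Compound 3 `Cn1cc([N+](=O)[O-])cc1C(=O)NNC(=S)NCc1ccccc1` gives 239000 nM in this assay. Among these three numbers compound 1 stands second highest; its nearest neighbour is compound 2, whose number is indistinguishable from it within the scatter, and its furthest is compound 3, still within the scatter. For the measured compounds named here, the one single-point step in the set, a 1.7-fold lower number from compound 1 to compound 3 (0.22 log units; within the scatter), concerns the substituent on an aromatic nitrogen of the shared core and lies within the scatter.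

Compound 4 `O=C(NNC(=S)NC1CCCCC1)c1cc([N+](=O)[O-])c[nH]1` is the next member to be measured in this assay. It differs from compound 1 in one place: cyclohexyl in place of benzyl on an amide-type nitrogen. Going by the values given here, no measured step touches the group on the amide-type nitrogen next to the thiocarbonyl carbon, so nothing speaks directly to this exchange. Among the compounds with values here, the only step available, from compound 1 to compound 3, is within the scatter and concerns a different position. On that basis the step is expected to be a 1.0-fold higher number from compound 1 to compound 4 (0.00 log units; within the scatter), with no direction beyond the scatter. Compound 4 is therefore estimated at 400000 nM in this assay, with a range from 200000 nM to 800000 nM.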

Compound 4, half-maximal inhibitory concentration: 204000 nM
The estimate for compound 4 lay 2.0-fold (0.29 log units) above the measured number; the range from low to high includes it.
By their numbers in this assay, from the lowest: compounds 4, 3, 1 and 2 (each within the scatter of the next).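

In this assay the position on the amide-type nitrogen whose other neighbour is the thiocarbonyl carbon now has a measured step of its own: cyclohexyl in place of benzyl gives a 1.9-fold lower number from compound 1 to compound 4 (0.29 log units; within the scatter) and so the exchange of a six-membered aromatic ring of carbon only for a non-aromatic one cannot be told apart from repeat scatter here. Together with the step on the aromatic nitrogen, a 1.7-fold lower number from compound 1 to compound 3 (0.22 log units; within the scatter) this means that neither of the two positions probed so far has moved the number beyond the scatter, although each position rests on a single exchange. No measurement at hand bears on why the numbers of this pair lie where they do.

Going by these compounds, what remains open is whether this position stays as flat for groups of another kind, such as an amine, a carboxylic acid or a longer chain in place of benzyl or cyclohexyl. Also open is how cyclohexyl on this nitrogen reads in combination with methyl on the aromatic nitrogen, since the compounds shown hold each exchange only on its own.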